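The source may hold more compounds than are shown below. What is called first, only, known or untested is meant among the compounds shown, and "the series" means these compounds.

Measured compounds in a functional assay on KG-1 cells (Homo sapiens) for antiproliferative activity; a higher number here means that more compound is needed for the effect, a lower number that less compound is needed:
compound 1, `NC(=O)c1cc(Cl)c2c(Cl)c(C#CC3CCCO3)n([C@H]3CCCNC3)c2n1`, 223 nM; 91 nM (2 entries)
compound 2, `NC(=O)c1cc(Cl)c2c(Cl)c(C#CC3CCOCC3)n([C@H]3CCCNC3)c2n1`, 69 nM
compound 3, `COC(C)(C)CC#Cc1c(Cl)c2c(Cl)cc(C(N)=O)nc2n1[C@H]1CCCNC1`, 172 nM

Going by the values given here, compound 3 gives the highest single number among the two compounds with a single value; its nearest neighbour is compound 2, and the step of a 2.5-fold higher number from compound 2 to compound 3 (0.40 log units; beyond the scatter) is the only one-place change measured in the set. Compound 1 has two entries, (the several entries of compound 1 in this assay, 223 nM; 91 nM (2 entries)), which shows how far repeated readings of one compound can fall apart.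

Compound 4, `CC(C)(O)C#Cc1c(Cl)c2c(Cl)cc(C(N)=O)nc2n1[C@H]1CCCNC1`, is not yet measured. It differs from compound 3 by 1-hydroxy-1-methylethyl in place of 2-methoxy-2-methylpropyl on a triple-bonded carbon. Among the compounds with values here, no measured step alters the group on the triple-bonded carbon in the same way; the step from compound 2 to compound 3 replaced a ring by an open chain and moved the number modestly upward. The change from compound 3 to compound 4 shortens the chain and exchanges a methoxy-bearing group for a hydroxy-bearing one, a change the set does not cover. The expectation is therefore a step of a 1.3-fold lower number from compound 3 to compound 4 (0.12 log units; within the scatter) close to the scatter, with the number for compound 4 expected near that of compound 3 or a little below it. Compound 4 is estimated at 130 nM, with a range from 50 nM to 350 nM.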

Compound 4, half-maximal effective concentration: 302 nM
Beside the measured number, compound 4's estimate is 2.3-fold (0.37 log units) below it, within the range that was stated.
By their numbers in this assay, from the lowest: compound 2; then compounds 3 and 4 (each within the scatter of the next).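

In this assay, putting 1-hydroxy-1-methylethyl in place of 2-methoxy-2-methylpropyl on the triple-bonded carbon gives a 1.8-fold higher number from compound 3 to compound 4 (0.24 log units; within the scatter), so this exchange of an ether-bearing chain for a hydroxy-bearing one, which adds a hydrogen-bond donor, does not separate the two compounds. Measured against oxan-4-yl, the same group gives a 4.4-fold higher number from compound 2 to compound 4 (0.64 log units; beyond the scatter), and together with a 2.5-fold higher number from compound 2 to compound 3 (0.40 log units; beyond the scatter) this places both open chains on the same side of compound 2, each beyond the scatter. Compound 1 also carries a ring on the triple-bonded carbon and goes against any simple reading of ring against open chain, since its readings do not agree on where it stands: the several entries of compound 1 in this assay, 223 nM; 91 nM (2 entries)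

The compounds shown leave open how an amine or a carboxylic acid on the triple-bonded carbon would read, and whether a longer chain ending in hydroxy would stay level with 1-hydroxy-1-methylethyl. Also open, as far as these compounds go, is whether the gap to compound 2 belongs to rings in general or to oxan-4-yl alone.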